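Trading the dichlorophenyl ring for a cyclohexyl ring

A few compounds are considered here, and "the series" means these few. Any claim that something is new, unique, unknown or untested is made for them only; others in the source may bear on it.

Of the compounds shown here, two share a common core and have been tested in a functional assay on A549 cells (Homo sapiens) for inhibition, read by XTT assay, with a stated time of 48 h; a lower number here means a stronger inhibitor, a higher number a weaker inhibitor. Compound 1 `COc1ccc(C(=O)/C(=C/c2ccc(Cl)cc2Cl)CC(C)OC(C)=O)cc1` gives 40300 nM in this assay. Within the data shown here, compound 2 `COc1ccc(C(=O)/C(=C/c2ccc(Cl)cc2Cl)CN(C)C(=O)c2ccccc2)cc1` gives 32400 nM in this assay, the lowest of the two numbers, though the single measured step, a 1.2-fold lower number from compound 1 to compound 2 (0.09 log units; within the scatter), lies within the scatter, so the two compounds cannot be told apart on these data.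

Compound 3 `COc1ccc(C(=O)/C(=C/C2CCCCC2)CN(C)C(=O)c2ccccc2)cc1` has not yet been measured. It differs from compound 2 in one place: cyclohexyl in place of 2,4-dichlorophenyl on a double-bonded chain carbon bound to a double-bonded chain carbon. Among the measured compounds shown here, the only measured step concerns a different position, the saturated chain carbon, and says nothing about exchanging the ring on the double-bonded chain carbon. For the measured compounds named here, there is therefore no measured step that bears on this change, and the expectation rests on the weak activity shared by compound 1 and compound 2.

On that basis the step from compound 2 to compound 3 is expected to be a 1.4-fold higher number from compound 2 to compound 3 (0.14 log units; within the scatter), no larger than the scatter. Compound 3 is accordingly estimated at 45000 nM in this assay, with a range from 15000 nM to 130000 nM.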

Compound 3, half-maximal inhibitory concentration: 69700 nM
Estimate against measurement, compound 3: 1.5-fold (0.19 log units) below; measured number inside the range.
By their numbers in this assay, from the lowest: compounds 2, 1 and 3 (each within the scatter of the next, the first and the last beyond it).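

In this assay, the change of ring on the double-bonded chain carbon gives a 2.2-fold higher number from compound 2 to compound 3 (0.33 log units; beyond the scatter), a modest step but one beyond the scatter. Among these compounds, compound 1 and compound 2 both carry 2,4-dichlorophenyl, so they could say nothing about this position; this pair is the first to show that the number responds to what sits there, and that cyclohexyl is the poorer of the two groups tested, though only by a small margin and with both compounds weak. The step swaps an aromatic ring for a non-aromatic one and removes both chlorine atoms at once, so it cannot be divided between those two differences, and no measurement available here explains it.

The compounds shown leave open which of the two differences matters: an unsubstituted phenyl ring at this position would keep the aromatic ring without the chlorine atoms, while a dichlorocyclohexyl group would do the reverse. Also open, on these data alone, is whether a ring is needed here at all, which a simple open chain such as a hexyl group could begin to test.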